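This account rests on a few compounds, and the source may have more. Where it says the series, first, only, none or still open, it means among the compounds named here.

Measured so far:
compound 1 `COC(=O)C1=CO[C@@H](O[C@@H]2O[C@H](CO)[C@@H](OC(C)=O)[C@H](OC(C)=O)[C@H]2OC(C)=O)[C@@H]2[C@@H](C)[C@@H](OC(C)=O)C[C@H]12`: "not active" (no number reported)
compound 2 `COC(=O)C1=CO[C@@H](O[C@@H]2O[C@H](COC(=O)C=C(C)C)[C@@H](OC(C)=O)[C@H](OC(C)=O)[C@H]2OC(C)=O)[C@@H]2[C@@H](C)[C@@H](OC(C)=O)C[C@H]12`: 0.65 ug/mL

Among the compounds with values here, in a functional assay on PA-1 cells (Homo sapiens) for cytotoxicity, read by MTT assay, with a stated time of 4 h (a lower number here means a stronger inhibitor, a higher number a weaker inhibitor), compound 2 gives 0.65 ug/mL, the only number, while compound 1 gives "not active" (no number reported). With a single number there is no ranking, and compound 2 serves as the sole numerical reference. The next analogue, compound 3 `COC(=O)C1=CO[C@@H](O[C@@H]2O[C@H](COC(=O)c3cccc([N+](=O)[O-])c3)[C@@H](OC(C)=O)[C@H](OC(C)=O)[C@H]2OC(C)=O)[C@@H]2[C@@H](C)[C@@H](OC(C)=O)C[C@H]12`, differs from compound 2 on a carbonyl carbon, with 3-nitrophenyl in place of 2-methylprop-1-en-1-yl on a carbonyl carbon. Within the data shown here, the series holds no measured step for a change of this kind, so the expectation is loose. A moderate shift towards weaker inhibition in this assay is expected, though a result within the usual scatter would not surprise. The estimated change is a 2.3-fold higher number from compound 2 to compound 3 (0.36 log units; beyond the scatter). For compound 3 the expected value is 1.5 ug/mL, with an estimated range of 0.4 ug/mL to 6 ug/mL.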

Compound 3, half-maximal inhibitory concentration: 0.85 ug/mL
The estimate for compound 3 lay 1.8-fold (0.25 log units) above the measured number, and the stated range covers the measured number.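

In this assay, 3-nitrophenyl in place of 2-methylprop-1-en-1-yl on a carbonyl carbon gives a 1.3-fold higher number from compound 2 to compound 3 (0.12 log units; within the scatter). The two groups differ in kind, one with no ring and 4 heavy atoms, the other with an aromatic ring, 9 heavy atoms and 2 hydrogen-bond acceptors, yet this read-out does not separate them. A measurable number at this place is therefore no longer tied to a single group, while compound 1, which has no acyl group here, gives "not active" (no number reported).

Still open is whether the nitro group contributes anything, as a plain phenyl is not among the compounds shown. A long saturated chain or an amine-bearing acyl group at this place is equally untested in the compounds shown. No measurement at hand accounts for this result.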